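Replacing a bulky ring amine with a small amide

The source may report more compounds than this note shows. Statements on the series, on what has been measured and on what is new or still open speak of the compounds shown alone.

Of the compounds shown here, three sharing one core have been measured in an assay for inhibition of Tryptophan 2,3-dioxygenase (Homo sapiens), with stated times of 10 min and 60 min, tested at 100 uM; on this read-out higher numbers stand for a stronger effect at the one concentration tested and lower numbers for a weaker effect. Compound 1, `O=[N+]([O-])c1cccc(CNc2cc(C(F)(F)F)cc3[nH]ncc23)c1`, carries a nitro group and gives 82%. Compound 2, `O=C(O)CNc1cccc(CNc2cc(C(F)(F)F)cc3[nH]ncc23)c1`, carries a (carboxymethyl)amino group in its place and gives 65%. Compound 3, `OC1CCCC(Nc2cccc(CNc3cc(C(F)(F)F)cc4[nH]ncc34)c2)C1`, carries a (3-hydroxycyclohexyl)amino group and gives 23%, which is the lowest of the three numbers. The step from compound 1 to compound 2 was a number 17 percentage points lower from compound 1 to compound 2 (beyond the scatter), and the step of a number 59 percentage points lower from compound 1 to compound 3 (beyond the scatter) was much larger, while the step of a number 42 percentage points lower from compound 2 to compound 3 (beyond the scatter) shows that the six-membered non-aromatic ring in compound 3 goes with a clearly weaker effect than the chain in compound 2.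

Compound 4, `CNC(=O)c1cccc(CNc2cc(C(F)(F)F)cc3[nH]ncc23)c1`, differs from compound 3 as follows: methylcarbamoyl in place of (3-hydroxycyclohexyl)amino on an aromatic carbon. The new group is small, like the nitro group of compound 1 and the chain of compound 2, both of which gave higher numbers than compound 3. Since the large drop came with a number 42 percentage points lower from compound 2 to compound 3 (beyond the scatter), the expectation is that removing the ring will raise the number again, with a step of about a number 32 percentage points higher from compound 3 to compound 4 (beyond the scatter) in this assay. Compound 4 is therefore estimated at 55%, within a range from 30% to 80%.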

Compound 4, a percentage reported as inhibition, at one concentration (the size of the read-out at that concentration, not a potency): 91%
For compound 4 the middle estimate is 36 percentage points below the measured one; the measured number lies above the stated range.
By their numbers in this assay, from the lowest: compound 3; then compound 2; then compounds 1 and 4 (each within the scatter of the next).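

In this assay, the largest change so far comes from swapping the (3-hydroxycyclohexyl)amino group for methylcarbamoyl on the aromatic carbon, with a number 68 percentage points higher from compound 3 to compound 4 (beyond the scatter), and the same group also outdoes the chain of the carboxylic acid compound, with a number 26 percentage points higher from compound 2 to compound 4 (beyond the scatter). Against the nitro group the change gives a number 9 percentage points higher from compound 1 to compound 4 (within the scatter), so compound 1 and compound 4 cannot be told apart, and this position therefore accepts two quite different groups, nitro and methylcarbamoyl, while keeping a high number. Nothing available explains why the ring-bearing group and the two groups without a ring differ in this way.

Going by these compounds, it remains open which part of the methylcarbamoyl group goes with the high number, the carbonyl, the amide hydrogen or the methyl; a primary amide, a dimethylamide, a carboxylic acid set directly on the ring or a longer amide chain at this position would help to separate them. On these data alone, each number is also the size of the effect at one concentration rather than a potency, so how compound 1 and compound 4 compare at lower concentrations stays unknown.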